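Hydroxy for Fluoro: Estimating the Effect of One Swap

The compounds below may be only part of what the source reports. "The series", "measured", "known", "first", "only" and "open" are said of these compounds alone.

In a functional assay on HCT-116 cells (Homo sapiens) for antiproliferative activity, with a stated time of 72 h (a lower number here means a stronger inhibitor, a higher number a weaker inhibitor), compound 3 (`C=C1C=CC(=O)[C@@H]2[C@H](Cc3ccc(F)c(F)c3)CC[C@H]12`) stands at 235 nM with compound 1 (`C=C1C=CC(=O)[C@@H]2[C@H](Cc3ccc(OCOC)cc3)CC[C@H]12`) at 129 nM within the scatter of it, so these two values cannot be told apart. Compound 2 (`C=C1C=CC(=O)[C@@H]2[C@H](Cc3cc(OC)c(OC)c(OC)c3)CC[C@H]12`) gives > 1000 nM as a limit of the assay and not as a number.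

Compound 4 (`C=C1C=CC(=O)[C@@H]2[C@H](Cc3ccc(O)c(F)c3)CC[C@H]12`) differs from compound 3 by hydroxy in place of fluoro on an aromatic carbon, ortho to a fluoro group and para to a large group. Within the data shown here, no measured pair shows this change, so in this assay compound 3 at 235 nM serves as the starting point. No step beyond the scatter is expected from compound 3. The expected change is a 1.1-fold higher number from compound 3 to compound 4 (0.03 log units; within the scatter) and it is only an estimate. The estimated value for compound 4 is 250 nM with an expected range from 90 nM to 700 nM for the measurement to come.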

Compound 4, half-maximal inhibitory concentration: 126 nM
Beside the measured number, compound 4's estimate is 2.0-fold (0.30 log units) above it, within the range that was stated.
By their numbers in this assay, from the lowest: compounds 4, 1 and 3 (each within the scatter of the next). At a limit, above all of these: compound 2.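

Hydroxy in place of fluoro gives a 1.9-fold lower number from compound 3 to compound 4 (0.27 log units; within the scatter) in this assay, so compound 3 and compound 4 cannot be told apart. Among these compounds, this is the first direct reading of this swap on an aromatic carbon ortho to a fluoro group and para to a large group. Here, the entering hydroxy counts one hydrogen-bond donor and the leaving fluoro none, with no step beyond the scatter.

As far as these compounds go, whether an amine or a carboxylic acid on this carbon would also stay within the scatter of compound 3 remains open. Nothing in the data given bears on why this result arises.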